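The source may hold more compounds than are shown below. What is called first, only, known or untested is meant among the compounds shown, and "the series" means these compounds.

Working notes on the acyl thiourea series. For the measured compounds named here, compound 1 `CC(=O)NC(=S)Nc1ccc(Br)c2ccccc12` and compound 2 `CC(C)(C)NC(=S)NC(=O)c1ccccc1` are the two measured members. In an assay for inhibition of epoxide hydrolase 1 (Homo sapiens), read by fluorescence, using microsomes (a lower number here means a stronger inhibitor, a higher number a weaker inhibitor), compound 1 gives 2420 nM; in this assay compound 2 gives 1580 nM. The two numbers lie within the scatter of each other, so no order between compound 1 and compound 2 can be read from them.

Compound 3 `O=C(NC(=S)Nc1ccc(Br)c2ccccc12)c1ccccc1` has not yet been measured in this assay. Relative to compound 1 the change is phenyl in place of methyl on a carbonyl carbon. Going by the values given here, no measured pair isolates this change, so the size of the step cannot be taken from the data; the expectation rests only on compound 2, which carries the same benzoyl group and gives 1580 nM. The step from compound 1 to compound 3 is therefore expected to be small, at most a modest decrease in the number, a 1.9-fold lower number from compound 1 to compound 3 (0.27 log units; within the scatter), with a fair chance that it falls within the scatter. For compound 3 the estimated value in this assay is 1300 nM, with a range from 400 nM to 4000 nM.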

Compound 3, half-maximal inhibitory concentration: 1880 nM
Beside the measured number, compound 3's estimate is 1.4-fold (0.16 log units) below it, and the stated range covers the measured number.
By their numbers in this assay, from the lowest: compounds 2, 3 and 1 (each within the scatter of the next).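

In this assay the series now has its first measured step at this position, and a 1.3-fold lower number from compound 1 to compound 3 (0.11 log units; within the scatter) stays within the scatter for phenyl in place of methyl on a carbonyl carbon. On the core of compound 1, a six-membered aromatic ring can therefore replace the methyl with no readable change in the number, so the position accepts a much larger group than methyl without a measurable loss or gain. No supporting measurement bears on the reason for this result.

This single pair does not show whether the same replacement behaves alike on another core. It also leaves open whether a different group on the carbonyl carbon, such as a longer chain, an amine or a carboxylic acid, would move the number beyond the scatter.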